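The compounds below may be only part of what the source reports. "The series", "measured", "known", "first", "only" and "open" are said of these compounds alone.

Working notes on the urea series sharing one core.

Compound 1 `O=C(Nc1ccc(Nc2ncnc3c2OCCN3)cc1)Nc1ccc(Cl)c(C(F)(F)F)c1` is the reference point: in an assay on isolated protein for inhibition of proto-oncogene tyrosine-protein kinase receptor Ret variant V804L (Homo sapiens), read by 33P incorporation, with stated times of 15 min and 40 min (on this read-out lower numbers stand for stronger inhibition and higher numbers for weaker inhibition), compound 1 gives 285 nM. Compound 2 `O=C(Nc1ccc(Nc2ncnc3c2OCCN3)cc1)Nc1ccc(C(F)(F)F)cc1` carries a 4-(trifluoromethyl)phenyl on the urea nitrogen in place of the 4-chloro-3-(trifluoromethyl)phenyl of compound 1, and in this assay compound 2 gives 2470 nM, the highest of the two numbers recorded so far, with compound 1 standing well beyond the usual scatter from it. For the measured compounds named here, no single-point step between measured compounds exists in this set, so the comparison of compound 1 with compound 2 rests on the two values alone.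

Compound 3 `O=C(Nc1ccc(Nc2ncnc3c2OCCN3)cc1)Nc1cc(Cl)cc(Cl)c1` is not yet measured. The change from compound 2 to compound 3 is 3,5-dichlorophenyl in place of 4-(trifluoromethyl)phenyl on an amide-type nitrogen. Going by the values given here, with only two measured compounds, the direction of this change is read from the fact that the halogenated aryl of compound 1, at 285 nM, sits far below compound 2. On that basis compound 3 is expected to move toward the lower end, with an estimated step of a 4.1-fold lower number from compound 2 to compound 3 (0.61 log units; beyond the scatter). Compound 3 is therefore estimated at 600 nM, within a range from 150 nM to 2500 nM.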

Compound 3, half-maximal inhibitory concentration: 4480 nM
Beside the measured number, compound 3's estimate is 7.5-fold (0.87 log units) below it, and the stated range ends below it.
By their numbers in this assay, from the lowest: compound 1; then compounds 2 and 3 (each within the scatter of the next).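

The exchange of 4-(trifluoromethyl)phenyl for 3,5-dichlorophenyl on an amide-type nitrogen gives a 1.8-fold higher number from compound 2 to compound 3 (0.26 log units; within the scatter) in this assay, so this assay does not separate these two aryl groups at this position. Chlorine on the aryl ring therefore does not by itself go with a low number: compound 1, with its 4-chloro-3-(trifluoromethyl)phenyl, gives 285 nM, while compound 3, with two chlorines and no trifluoromethyl, gives 4480 nM. Nothing available bears on why these aryl groups give the numbers they do.

The compounds shown leave open whether the number of compound 1 depends on chlorine and trifluoromethyl standing together on one ring, or on the particular placement of these groups, since compound 2 and compound 3 each differ from it in more than one feature of the aryl group. Also open, going by these compounds, is how the series reads in this assay when the aryl group carries something other than halogen or trifluoromethyl, such as a methoxy group, an amine or a carboxylic acid.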